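Losing the piperazine chain from compound 2

The compounds below may be only part of what the source reports. "The series", "measured", "known", "first", "only" and "open" are said of these compounds alone.

Compound 1 `CC(C)c1n[nH]c2c(NCc3ccc(-c4ccccn4)cc3)nc(SCC(O)C(F)(F)F)nc12`: 690 nM
Compound 2 `CC(C)c1n[nH]c2c(NCc3ccc(-c4ccccn4)cc3)nc(SCC(O)CN3CCNCC3)nc12`: 332 nM

In a functional assay on HT cells (Homo sapiens) for antiproliferative activity, read by fluorescence, with a stated time of 72 h (on this read-out higher numbers stand for weaker inhibition of growth and lower numbers for stronger inhibition of growth), compound 2 gives the lower number of the two. Compound 3 `CSc1nc(NCc2ccc(-c3ccccn3)cc2)c2[nH]nc(C(C)C)c2n1` is still unmeasured and differs from compound 2 by one change: hydrogen in place of 1-hydroxy-2-(piperazin-1-yl)ethyl on a saturated chain carbon bound to a sulfur. Going by the values given here, the one measured step that bears on this, a 2.1-fold lower number from compound 1 to compound 2 (0.32 log units; beyond the scatter), was modest and altered the same chain. Among the compounds with values here, no measured compound shows the shorter methylsulfanyl chain, so a modest step toward a higher number is expected, with wide uncertainty. The expected step is a 2.0-fold higher number from compound 2 to compound 3 (0.29 log units; within the scatter). For compound 3 the estimated value is 650 nM, within an expected range of 220 nM to 1900 nM.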

Compound 3, concentration for 50% growth inhibition: 783 nM
Compound 3: the middle estimate sits 1.2-fold (0.08 log units) below what was measured; the range from low to high includes it.
By their numbers in this assay, from the lowest: compound 2; then compounds 1 and 3 (each within the scatter of the next).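

In this assay the step to the methylsulfanyl group is a 2.4-fold higher number from compound 2 to compound 3 (0.37 log units; beyond the scatter). This step lies beyond the scatter. The same cut made on the trifluoromethyl chain is a 1.1-fold higher number from compound 1 to compound 3 (0.05 log units; within the scatter) and shows no change. Of these three chains, only 2-hydroxy-3-(piperazin-1-yl)propyl stands apart from methyl in this series.

As far as these compounds go, whether a morpholine ring, a dimethylamino group or a carboxylic acid in place of the piperazine would do the same stays open. Nothing available explains why the piperazine chain differs from the other two.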